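Aryl swaps on the shared core leave inhibition flat

The source may hold more compounds than are shown below. What is called first, only, known or untested is meant among the compounds shown, and "the series" means these compounds.

Measured in an assay on CHO cells for displacement of a labelled ligand from adenosine receptor A3 (Homo sapiens), read by scintillation counting, tested at 10 uM; on this read-out lower numbers stand for less inhibition and higher numbers for more inhibition at the one concentration tested (going by the name of the read-out):
compound 1 `CC(C)(C)Cc1c(-c2ccoc2)sc(N)c1C(=O)c1ccc(Cl)cc1` gives 1%
compound 2 `CC(C)(C)Cc1c(-c2ccccn2)sc(N)c1C(=O)c1ccc(Cl)cc1` gives 1%
compound 3 `COc1ccccc1-c1sc(N)c(C(=O)c2ccc(Cl)cc2)c1CC(C)(C)C` gives 1%

Compound 1 stands level with compounds 2 and 3 at the digits shown in this assay. The three measured steps each exchange the aryl group on the ring carbon of the shared core: no change at the digits printed from compound 1 to compound 2 (within the scatter), no change at the digits printed from compound 1 to compound 3 (within the scatter) and no change at the digits printed from compound 2 to compound 3 (within the scatter). None of them moves the read-out beyond the scatter.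

Compound 4 `CC(C)(C)Cc1c(-c2ccccc2)sc(N)c1C(=O)c1ccc(Cl)cc1` is not yet measured. It differs from compound 1 by phenyl in place of furan-3-yl on an aromatic carbon. The three measured exchanges at this same carbon bear directly on this step, and all of them were flat. The step of no change at the digits printed from compound 1 to compound 4 (within the scatter) is therefore expected to show no change beyond the scatter. Compound 4 is estimated at 1% in this assay, with a range from -6% to 10%.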

Compound 4, a percentage reported as inhibition, at one concentration (the size of the read-out at that concentration, not a potency): 1%
Compound 4: the middle estimate sits on the measured number at the digits printed; measured number inside the range.
By their numbers in this assay, from the lowest: compounds 1, 2, 3 and 4 (each within the scatter of the next).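

In this assay phenyl on this carbon gives no change at the digits printed from compound 1 to compound 4 (within the scatter) and no change at the digits printed from compound 2 to compound 4 (within the scatter), so a six-membered aromatic ring of carbon only reads the same as the ring groups that carry a hetero atom. Hydrogen in place of methoxy on the aryl ring also gives no change at the digits printed from compound 3 to compound 4 (within the scatter), which extends the flat picture to the unsubstituted ring. No measurement bears on why these exchanges leave the read-out flat.

From the compounds shown here alone, whether an aminomethyl or a carboxylic acid on this carbon would move the read-out remains open. So does the effect of a longer chain in place of the neopentyl group.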